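Dichloro Substitution on the Sulfonamide Benzyl Group

The source may hold more compounds than are shown below. What is called first, only, known or untested is meant among the compounds shown, and "the series" means these compounds.

Measured compounds:
compound 1, `O=S1(=O)N=C(OCc2ccccc2)c2ccccc2N1Cc1ccccc1`, 22200 nM
compound 2, `O=C1c2ccccc2N(Cc2ccc(Cl)cc2)S(=O)(=O)N1Cc1ccccc1`, 19700 nM
compound 3, `O=C1c2ccccc2N(Cc2ccc(Cl)cc2)S(=O)(=O)N1Cc1ccc(Cl)cc1`, 35800 nM

All three compounds were tested in a functional assay on CCRF-CEM cells (Homo sapiens) for inhibition; on this read-out lower numbers stand for higher toxicity in this test and higher numbers for lower toxicity in this test. Compound 1 stands second highest of the three numbers; its nearest neighbour is compound 2, and the gap between them, as between compound 1 and compound 3, lies within the scatter of repeated measurements. Within the data shown here, the single one-place step among the measured compounds, a 1.8-fold higher number from compound 2 to compound 3 (0.26 log units; within the scatter), introduces a chloro group on the benzyl attached to the carbonyl-side nitrogen of the core and stays within the scatter.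

Compound 4, `O=S1(=O)N=C(OCc2ccccc2)c2ccccc2N1Cc1ccc(Cl)c(Cl)c1`, has not yet been measured. It differs from compound 1 by 3,4-dichlorophenyl in place of phenyl on a saturated chain carbon bound to a sulfonamide nitrogen in a ring. Among the measured compounds shown here, this change sits on the other benzyl group than the one altered in the step from compound 2 to compound 3, so that step bears on it only loosely; it does show that adding a chloro to a benzyl of this core did not move the number beyond the scatter. Compound 4 is therefore expected to give a number close to that of compound 1, with the step of a 1.1-fold higher number from compound 1 to compound 4 (0.05 log units; within the scatter) estimated to stay within the scatter. The estimate for compound 4 is 25000 nM, with a range from 10000 nM to 60000 nM.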

Compound 4, half-maximal cytotoxic concentration: 30500 nM
Compound 4: the middle estimate sits 1.2-fold (0.09 log units) below what was measured; the range from low to high includes it.
By their numbers in this assay, from the lowest: compounds 2, 1, 4 and 3 (each within the scatter of the next).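

Among these compounds, with 3,4-dichlorophenyl in place of phenyl on a saturated chain carbon bound to a sulfonamide nitrogen in a ring, a 1.4-fold higher number from compound 1 to compound 4 (0.14 log units; within the scatter) gives the first direct reading of a change at this place in this assay. Among the compounds shown here, the result shows that this place accepts the larger dichlorinated group without the number leaving the scatter, much as the single chloro change in a 1.8-fold higher number from compound 2 to compound 3 (0.26 log units; within the scatter) stayed within it at its own place. Nothing measured here offers an explanation for this result.

From the compounds shown here alone, whether a carboxylic acid or an amine on this phenyl ring, or a longer chain in place of the benzyl, would carry the number in this assay beyond the scatter remains open. Going by these compounds, how the other benzyl of compound 1 responds to any change also remains open.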